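Fluoro in place of hydrogen on a uridine analogue

The source may report more compounds than this note shows. Statements on the series, on what has been measured and on what is new or still open speak of the compounds shown alone.

Measured so far:
compound 1 `Cc1c(F)c(=O)[nH]c(=O)n1C1O[C@H](CO)[C@@H](O)[C@H]1O` — 7.7
compound 2 `O=c1cc(CO)n(C2O[C@H](CO)[C@@H](O)[C@H]2O)c(=O)[nH]1` — 9.8

In an ADME assay, compound 2 gives the higher of the two numbers, and compound 1 gives a number well below it, a gap beyond the scatter. Compound 3 `O=c1[nH]c(=O)n(C2O[C@H](CO)[C@@H](O)[C@H]2O)c(CO)c1F` is not yet measured. Its change from compound 2 is fluoro in place of hydrogen on an aromatic carbon. Because compound 1, which also carries fluoro, gives 7.7, a downward step of a number 2.00 log units lower from compound 2 to compound 3 (beyond the scatter) is expected. Compound 3 is therefore estimated at 7.8, between 7.3 and 8.4.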

Compound 3, acid dissociation constant: 7.9
Compound 3: the middle estimate sits 0.10 log units below what was measured, within the range that was stated.
By their numbers in this assay, from the lowest: compounds 1 and 3 (each within the scatter of the next); then compound 2.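

In this assay, among these compounds, fluoro in place of hydrogen on the aromatic carbon gives a number 1.90 log units lower from compound 2 to compound 3 (beyond the scatter) on a core carrying the hydroxymethyl group, the first direct reading of this change. Hydroxy in place of hydrogen on the saturated chain carbon bound to that ring gives a number 0.20 log units higher from compound 1 to compound 3 (within the scatter), so with fluoro present, the two compounds cannot be told apart here. From the compounds shown here alone, only hydrogen and fluoro have been seen at this position, so how chloro, a nitrile or an amine there would compare remains open. Nothing available explains the size of the fluoro step.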